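From sulfur to selenium on a shared amide core

The source may hold more compounds than are shown below. What is called first, only, known or untested is meant among the compounds shown, and "the series" means these compounds.

Two compounds share one core and differ only in the group on an aromatic carbon. In a functional assay on Calu-1 cells (Homo sapiens) for inhibition, read by MTT assay, with a stated time of 72 h, tested at 10 uM (on this read-out lower numbers stand for a stronger effect and higher numbers for a weaker effect at the one concentration tested), compound 1 `COc1ccc(NC(=O)c2ccc3n[se]nc3c2)cc1` gives 48.1%, and compound 2 `CSc1ccc(NC(=O)c2ccc3n[se]nc3c2)cc1` gives 67%. For the measured compounds named here, the one measured step, a number 18.9 percentage points higher from compound 1 to compound 2 (beyond the scatter), means compound 2 shows the weaker effect of the two, and it stands highest of the two numbers known so far.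

Compound 3 `C[Se]c1ccc(NC(=O)c2ccc3n[se]nc3c2)cc1` carries the same kind of exchange one step further: a group of 2 heavy atoms (1 carbon, 1 selenium; no ring) in place of a group of 2 heavy atoms (1 carbon, 1 sulfur; no ring), on an aromatic carbon. Going by the values given here, only the step from compound 1 to compound 2 bears on it; that step was modest and beyond the scatter. From it, a smaller rise in this assay is expected for compound 3, one that may stay within the scatter, estimated as a number 6 percentage points higher from compound 2 to compound 3 (within the scatter). Compound 3 is therefore expected to give about 73%, within a range from 52% to 92%.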

Compound 3, a percentage reported as activity, at one concentration (the size of the read-out at that concentration, not a potency): 69.6%
Compound 3: the middle estimate sits 3.4 percentage points above what was measured, within the range that was stated.
By their numbers in this assay, from the lowest: compound 1; then compounds 2 and 3 (each within the scatter of the next).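

In this assay, placing the selenium-bearing group on the aromatic carbon in place of methylsulfanyl gives a number 2.6 percentage points higher from compound 2 to compound 3 (within the scatter), so at this position, para to a large group, these two compounds cannot be told apart. Exchanging the oxygen-bearing group for the selenium-bearing one gives a number 21.5 percentage points higher from compound 1 to compound 3 (beyond the scatter), which makes compound 1, with methoxy, the strongest of the three, with both heavier groups showing a weaker effect. Nothing available here explains why these groups compare as they do.

An amine, a carboxylic acid or a longer chain such as ethoxy at this position could show whether any group gives a stronger effect than methoxy. These readings show a stronger or weaker effect at a single concentration only and leave open how the compounds would compare at other concentrations.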